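Dimethylamino for isobutyl on the sulfonyl sulfur

The source may report more compounds than this note shows. Statements on the series, on what has been measured and on what is new or still open speak of the compounds shown alone.

Readings so far in an ADME assay on a cell-free system (plasma, Mus musculus); on this read-out higher numbers stand for a larger free fraction and lower numbers for a smaller free fraction:
Compound 1 (`Cc1ccc(S(=O)(=O)NC(C)C)cc1C#Cc1cc(Cl)ccc1OCC(=O)O`) gives 0.01
Compound 2 (`Cc1ccc(S(=O)(=O)CC(C)C)cc1C#Cc1cc(Cl)ccc1OCC(=O)O`) gives "not determined" (no result reported)

Compound 2 has no single number, so the step that follows has no measured starting point. Compound 3 (`Cc1ccc(S(=O)(=O)N(C)C)cc1C#Cc1cc(Cl)ccc1OCC(=O)O`) carries dimethylamino in place of isobutyl on a sulfonyl sulfur, a change counted as dimethylamino in place of isobutyl on a sulfonyl sulfur, and the rest of the structure stays the same. Among the compounds with values here, with no measured step to go by and no value for compound 2, the size of the shift cannot be read from the data. Within the data shown here, the only anchor is compound 1 at 0.01, and compound 3 is expected to stay near that reading, with no difference beyond the scatter of this assay. In this assay compound 3 is estimated at 0.01, with an expected range from 0.004 to 0.03.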

Compound 3, unbound fraction: 0.01
The estimate for compound 3 equals the measured number at the digits printed, and the stated range covers the measured number.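

In this assay, within the data shown here, dimethylamino in place of isopropylamino on a sulfonyl sulfur gives no change at the digits printed from compound 1 to compound 3 (within the scatter), the first comparison at this position with a number at both ends, and it shows that these two amino groups cannot be told apart on this read-out. Compound 2 has no single number, so the step from the isobutyl group to dimethylamino cannot be read, and the comparison with a carbon-linked group stays empty. Nothing at hand bears on why the two amino compounds read alike.

The compounds shown leave open whether morpholine or a longer chain such as n-hexyl on the sulfonyl sulfur would read apart from compound 1 and compound 3. They also leave open how a plain unsubstituted amino group there would read.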